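Pyridin-3-yl in place of 4-fluorophenyl on compound 1

This account rests on a few compounds, and the source may have more. Where it says the series, first, only, none or still open, it means among the compounds named here.

In a functional assay on A549 cells (Homo sapiens) for antiproliferative activity, read by sulforhodamine B assay, with a stated time of 48 h (on this read-out lower numbers stand for stronger inhibition and higher numbers for weaker inhibition), compound 1 `COc1ccc(/C=C/C(=O)c2ccccc2-c2ccc(F)cc2)cc1` gives 140 nM. Compound 3 `COc1ccc(/C=C/C(=O)c2ccccc2-c2ccc(F)cc2)cc1B(O)O` gives 82 nM, and the step is a 1.7-fold lower number from compound 1 to compound 3 (0.23 log units; within the scatter). Among the compounds with values here, compound 2 `COc1ccc(/C=C/C(=O)c2ccccc2-c2ccc(F)cc2)cc1O` gives 65 nM, the only value apart from compound 1 beyond the scatter: a 2.2-fold lower number from compound 1 to compound 2 (0.33 log units; beyond the scatter). Compound 4 `COc1ccc(/C=C/C(=O)c2ccccc2-c2cccnc2)cc1` differs from compound 1 by pyridin-3-yl in place of 4-fluorophenyl on an aromatic carbon. Neither measured step touches the 4-fluorophenyl, so both serve only as a scale of size, and no measurement fixes the direction. A modest rise is the tentative expectation, and the estimated step is a 1.6-fold higher number from compound 1 to compound 4 (0.20 log units; within the scatter). Compound 4 is estimated at 220 nM, with an expected range of 70 nM to 700 nM.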

Compound 4, half-maximal inhibitory concentration: 580 nM
For compound 4 the middle estimate is 2.6-fold (0.42 log units) below the measured one; the measured number falls inside the stated range.
By their numbers in this assay, from the lowest: compounds 2, 3 and 1 (each within the scatter of the next, the first and the last beyond it); then compound 4.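

In this assay, within the data shown here, replacing 4-fluorophenyl with pyridin-3-yl gives the first step toward a higher number that lies beyond the scatter: a 4.1-fold higher number from compound 1 to compound 4 (0.62 log units; beyond the scatter). The earlier compounds shown here all carry 4-fluorophenyl, so only this result shows that the read-out responds to the ring on this aromatic carbon, ortho to a large group. No available evidence bears on the reason for this rise.

Still open, on these data alone, is whether the rise follows the entering ring nitrogen or the departing fluorine, and a plain phenyl ring would separate the two. Also open, as far as these compounds go, is how an amine on this ring would read.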